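From Carboxy to Carboxymethyl in an Antiproliferative Pair

A few compounds are considered here, and "the series" means these few. Any claim that something is new, unique, unknown or untested is made for them only; others in the source may bear on it.

In a functional assay on NCI-H929 cells (Homo sapiens) for antiproliferative activity, with a stated time of 24 h (a higher number here means a weaker inhibitor, a lower number a stronger inhibitor), compound 1 (`COc1ccc(F)cc1-c1ccnc2[nH]c(C3=CCC(C(=O)NS(C)(=O)=O)CC3)cc12`) gives 1100 nM, and compound 2 (`COc1ccc(F)cc1-c1ccnc2[nH]c(C3=CCC(N4CCC(C(=O)O)CC4)CC3)cc12`) gives 170 nM, the lower of the two numbers. The next analogue, compound 3 (`COc1ccc(F)cc1-c1ccnc2[nH]c(C3=CCC(N4CCC(CC(=O)O)CC4)CC3)cc12`), differs from compound 2 in one place: carboxymethyl in place of carboxy on a saturated ring carbon. In words, this is carboxymethyl in place of carboxy on a saturated ring carbon, three ring bonds from the ring nitrogen. For the measured compounds named here, only one measured step bears on this change, and only loosely: a 6.5-fold lower number from compound 1 to compound 2 (0.81 log units; beyond the scatter), with 4-carboxypiperidin-1-yl in place of (methylsulfonyl)carbamoyl. That step exchanged a whole group, whereas this one keeps the piperidine and the acid, so a smaller step with no firm direction is expected, probably none beyond the scatter. The expectation therefore rests on compound 2 at 170 nM. The estimate for compound 3 is 200 nM, with an expected range from 70 nM to 570 nM. This amounts to an expected 1.2-fold higher number from compound 2 to compound 3 (0.07 log units; within the scatter).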

Compound 3, half-maximal inhibitory concentration: 240 nM
Compound 3: the middle estimate sits 1.2-fold (0.08 log units) below what was measured; the measured number falls inside the stated range.
By their numbers in this assay, from the lowest: compounds 2 and 3 (each within the scatter of the next); then compound 1.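

In this assay, carboxymethyl in place of carboxy on a saturated ring carbon, three ring bonds from the ring nitrogen, gives a 1.4-fold higher number from compound 2 to compound 3 (0.15 log units; within the scatter), so at this position the acid can stand one carbon further out with no readable shift in the number. Exchanging (methylsulfonyl)carbamoyl for 4-(carboxymethyl)piperidin-1-yl gives a 4.6-fold lower number from compound 1 to compound 3 (0.66 log units; beyond the scatter), which shows that the gain seen with 4-carboxypiperidin-1-yl also appears with this longer group. No evidence in hand accounts for either result.

The compounds shown leave open whether a longer chain, such as carboxyethyl, would keep the number at this level. They also do not tell whether the carboxylic acid itself is needed on this ring carbon, or whether a primary amide, a tetrazole or a hydroxymethyl group could stand in its place.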